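Giving up 2,4-dichlorophenyl: what compound 4 may show

The compounds below may be only part of what the source reports. "The series", "measured", "known", "first", "only" and "open" are said of these compounds alone.

Values so far in a functional assay on ACHN cells (Homo sapiens) (on this read-out higher numbers stand for weaker inhibition of growth and lower numbers for stronger inhibition of growth), are these:
Compound 1 `O=S(=O)(/C=C/c1ccccc1)Cc1ccc(Nc2ncnc3ccccc23)cc1` gives 58000 nM
Compound 2 `N#Cc1ccc(/C=C/S(=O)(=O)Cc2ccc(Nc3ncnc4ccccc34)cc2)cc1` gives > 100000 nM which is a limit of the assay
Compound 3 `O=S(=O)(/C=C/c1ccc(Cl)cc1Cl)Cc1ccc(Nc2ncnc3ccccc23)cc1` gives 100 nM

Compound 3 stands lowest of the numbers shown at 100 nM and compound 1 is nearest at 58000 nM on the same scale. Compound 4 `O=S(=O)(/C=C/c1ccc(O)cc1)Cc1ccc(Nc2ncnc3ccccc23)cc1` is not yet measured and differs from compound 3 as follows: 4-hydroxyphenyl in place of 2,4-dichlorophenyl on a double-bonded chain carbon bound to a double-bonded chain carbon. Among the measured compounds shown here, two measured steps bear on this, both large and beyond the scatter: a 580-fold lower number from compound 1 to compound 3 (2.76 log units; beyond the scatter) and an at least 1000-fold lower number from compound 2 to compound 3 (3.00 log units; beyond the scatter). Each brings in 2,4-dichlorophenyl, which compound 4 gives up, while the floor of an at least 1.7-fold higher number from compound 1 to compound 2 (0.23 log units; that floor lies within the scatter) stays within the scatter. A large move to a higher number is therefore expected in this assay, with a 300-fold higher number from compound 3 to compound 4 (2.48 log units; beyond the scatter) as the estimated step. Compound 4 is estimated at 30000 nM, with an expected range from 3000 nM to 100000 nM.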

Compound 4, concentration for 50% growth inhibition: 20 nM
Compound 4: middle estimate off by 1500-fold (3.18 log units), on the high side; measured number outside the range, below it.
By their numbers in this assay, from the lowest: compound 4; then compound 3; then compound 1. At a limit, above all of these: compound 2.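

In this assay, the 2,4-dichlorophenyl group proves not to be the only route to strong inhibition of growth at this place: 4-hydroxyphenyl gives a 5.0-fold lower number from compound 3 to compound 4 (0.70 log units; beyond the scatter). A hydroxy group alone in place of hydrogen gives a 2900-fold lower number from compound 1 to compound 4 (3.46 log units; beyond the scatter), so a single change on the aromatic ring is enough for a large move. Hydroxy in place of cyano gives an at least 5000-fold lower number from compound 2 to compound 4 (3.69 log units; beyond the scatter), a floor only, with compound 2 at a limit: the limit of > 100000 nM in this assay, at which 1 of the 4 values shown sits.

From the compounds shown here alone, what a methoxy group or an amine would give in place of hydroxy stays open. So does how much each chlorine contributes to the value of compound 3.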